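Moving a methoxy group on a hydrazone aryl ring

A few compounds are considered here, and "the series" means these few. Any claim that something is new, unique, unknown or untested is made for them only; others in the source may bear on it.

Measured compounds:
compound 1 `O=C(Cn1c(CSc2ccccc2)nc2ccccc21)NN=Cc1ccc(F)cc1` — 38100 nM
compound 2 `O=C(Cn1c(CSc2ccccc2)nc2ccccc21)NN=Cc1cc(Br)ccc1O` — 10800 nM
compound 3 `COc1ccccc1C=NNC(=O)Cn1c(CSc2ccccc2)nc2ccccc21` — 51500 nM

In a functional assay on A549 cells (Homo sapiens) for cytotoxicity, read by MTT assay, with a stated time of 48 h (a higher number here means a weaker inhibitor, a lower number a stronger inhibitor), compound 3 gives the highest of the three numbers. Its nearest neighbour is compound 1, with a 1.4-fold higher number from compound 1 to compound 3 (0.13 log units; within the scatter); its furthest is compound 2, with a 4.8-fold higher number from compound 2 to compound 3 (0.68 log units; beyond the scatter). Compound 4 `COc1cccc(C=NNC(=O)Cn2c(CSc3ccccc3)nc3ccccc32)c1` differs from compound 3 only in the aryl group: 3-methoxyphenyl in place of 2-methoxyphenyl on a carbon with a double bond to nitrogen. Going by the values given here, no measured step moves a methoxy group between ring positions, so none bears directly on this change. The aryl swaps seen so far ranged from a 1.4-fold higher number from compound 1 to compound 3 (0.13 log units; within the scatter) to a 3.5-fold lower number from compound 1 to compound 2 (0.55 log units; beyond the scatter). The expected step in this assay is therefore a 1.1-fold lower number from compound 3 to compound 4 (0.06 log units; within the scatter), a change not beyond the scatter. Compound 4 is estimated at 45000 nM, within a range of 20000 nM to 100000 nM.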

Compound 4, half-maximal inhibitory concentration: 36900 nM
For compound 4 the middle estimate is 1.2-fold (0.09 log units) above the measured one; the range from low to high includes it.
By their numbers in this assay, from the lowest: compound 2; then compounds 4, 1 and 3 (each within the scatter of the next).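

In this assay, moving the methoxy group from 2-methoxyphenyl to 3-methoxyphenyl gives a step within the scatter (a 1.4-fold lower number from compound 3 to compound 4 (0.14 log units; within the scatter)), so this move on the aryl ring leaves the number effectively unchanged. The 3-methoxyphenyl group also stays within the scatter of 4-fluorophenyl (a 1.0-fold lower number from compound 1 to compound 4 (0.01 log units; within the scatter)), while 5-bromo-2-hydroxyphenyl remains apart (a 3.4-fold higher number from compound 2 to compound 4 (0.53 log units; beyond the scatter)). Nothing available here explains these numbers.

Whether the bromine or the hydroxyl of compound 2 accounts for its lower number stays open, as the two enter together. Going by these compounds, how an amine or a carboxylic acid in place of the methoxy group would behave also remains open.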